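The source may report more compounds than this note shows. Statements on the series, on what has been measured and on what is new or still open speak of the compounds shown alone.

Among the compounds with values here, in a functional assay (aorta) with Rattus norvegicus as the target (on this read-out higher numbers stand for weaker inhibition and lower numbers for stronger inhibition), compound 3 `CCCN(CCC)CCCOc1ccc(S(=O)(=O)c2c(C)cn3ccccc23)cc1` gives 957 nM, the highest number so far. Compound 1 `CC(C)c1cn2ccccc2c1S(=O)(=O)c1ccc(OCCCNCc2ccccc2)cc1` gives 22.8 nM and compound 2 `CCCCN(CCCC)CCCCOc1ccc(S(=O)(=O)c2c(C(C)C)cn3ccccc23)cc1` gives 20.2 nM. The gap from compound 3 to each of these two lies beyond the scatter. Compound 4 `CCCN(CCC)CCCOc1ccc(S(=O)(=O)c2c(C(C)C)cn3ccccc23)cc1` differs from compound 3 in one place: isopropyl in place of methyl on an aromatic carbon. Within the data shown here, no measured step covers this exchange. The only one, a 1.1-fold lower number from compound 1 to compound 2 (0.05 log units; within the scatter), lies on the chain and stays within the scatter. Compound 1 and compound 2 both carry isopropyl, but they also differ from compound 3 on the chain, so the evidence is indirect. A clear fall is nevertheless expected, with an estimated 27-fold lower number from compound 3 to compound 4 (1.44 log units; beyond the scatter). The estimate for compound 4 is 35 nM, with an expected range of 10 nM to 120 nM.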

Compound 4, half-maximal inhibitory concentration: 102 nM
Compound 4: the middle estimate sits 2.9-fold (0.46 log units) below what was measured; measured number inside the range.
By their numbers in this assay, from the lowest: compounds 2 and 1 (each within the scatter of the next); then compound 4; then compound 3.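

In this assay, the change from methyl to isopropyl on this aromatic carbon now has a direct reading with the rest of the molecule unchanged, giving a 9.4-fold lower number from compound 3 to compound 4 (0.97 log units; beyond the scatter). The chain also matters with isopropyl in place, with a 5.0-fold higher number from compound 2 to compound 4 (0.70 log units; beyond the scatter) and a 4.5-fold higher number from compound 1 to compound 4 (0.65 log units; beyond the scatter), although the step between compound 1 and compound 2 stayed within the scatter. Nothing available explains these steps.

The methyl partners of compound 1 and compound 2 are not among the compounds shown, so it remains open whether the isopropyl step holds on those chains. Going by these compounds, how tert-butyl or phenyl would read at this position also remains open.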